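Shifting a hydroxyl within the ester side chain

The compounds below may be only part of what the source reports. "The series", "measured", "known", "first", "only" and "open" are said of these compounds alone.

Measured compounds:
compound 1 `C=C1C(=O)O[C@@H]2[C@H]3O[C@]3(C)CC/C=C(\C)[C@@H](OC(=O)C(C)(O)CC)C[C@@H]12`, 7.1 ug/mL
compound 2 `C=C1C(=O)O[C@@H]2[C@H]3O[C@]3(C)CC/C=C(\C)[C@@H](OC(=O)CC(C)(C)O)C[C@@H]12`, 14.1 ug/mL

Compound 2 `C=C1C(=O)O[C@@H]2[C@H]3O[C@]3(C)CC/C=C(\C)[C@@H](OC(=O)CC(C)(C)O)C[C@@H]12` has the highest of the two numbers in a functional assay on HCT-116 cells (Homo sapiens) for cytotoxicity, read by MTT assay, with a stated time of 48 h; a higher number here means a weaker inhibitor, a lower number a stronger inhibitor; its nearest neighbour is compound 1 `C=C1C(=O)O[C@@H]2[C@H]3O[C@]3(C)CC/C=C(\C)[C@@H](OC(=O)C(C)(O)CC)C[C@@H]12`, and the step of a 2.0-fold higher number from compound 1 to compound 2 (0.30 log units; within the scatter) lies within the scatter, so the two are not told apart by this assay. The unmeasured compound 3 `C=C1C(=O)O[C@@H]2[C@H]3O[C@]3(C)CC/C=C(\C)[C@@H](OC(=O)C(C)C(C)O)C[C@@H]12` differs from compound 2 in one place: 2-hydroxy-1-methylpropyl in place of 2-hydroxy-2-methylpropyl on a carbonyl carbon. Within the data shown here, the only measured step that bears on this, from compound 1 to compound 2, also reworks the same side chain and gave a step within the scatter. Compound 3 is therefore expected to stay near compound 2, with the estimated step of a 1.3-fold lower number from compound 2 to compound 3 (0.11 log units; within the scatter) not beyond the scatter. For compound 3 the expected number in this assay is 11 ug/mL, with a range from 4 ug/mL to 28 ug/mL.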

Compound 3, half-maximal inhibitory concentration: 0.39 ug/mL
Beside the measured number, compound 3's estimate is 28-fold (1.45 log units) above it, outside the stated range (below it).
By their numbers in this assay, from the lowest: compound 3; then compounds 1 and 2 (each within the scatter of the next).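

The side chain on this carbonyl carbon proved far more sensitive to rearrangement in this assay than the earlier pair suggested: the step of a 2.0-fold higher number from compound 1 to compound 2 (0.30 log units; within the scatter) had not told two arrangements apart, yet 2-hydroxy-1-methylpropyl separates clearly from both earlier side chains (a 36-fold lower number from compound 2 to compound 3 (1.56 log units; beyond the scatter)) and (an 18-fold lower number from compound 1 to compound 3 (1.26 log units; beyond the scatter)). All three chains carry the same atoms and the same counts of donors and acceptors, so the large steps here come with a change in how those atoms are joined and not in what they are. Nothing available accounts for this gap.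

As far as these compounds go, it remains open whether the low number of compound 3 depends on the hydroxyl itself or would persist with an amine in its place. From the compounds shown here alone, it is equally open whether a longer chain carrying the same branching would keep it.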